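Ring size on the aromatic nitrogen: compound 3 expected

This account rests on a few compounds, and the source may have more. Where it says the series, first, only, none or still open, it means among the compounds named here.

Measured so far:
compound 1 `CC(C)c1onc(-c2c(Cl)cccc2Cl)c1COc1ccc(-c2nc3ccc(C(=O)O)cc3n2C2CCCCCC2)cc1` — 14.8 nM
compound 2 `CC(C)c1onc(-c2c(Cl)cccc2Cl)c1COc1ccc(-c2nc3ccc(C(=O)O)cc3n2C2CCC2)cc1` — 14.4 nM

Both were tested in an assay on Huh-7 cells for agonist activity at Bile acid receptor (Homo sapiens), read by a luciferase reporter; a lower number here means that less compound is needed, a higher number that more compound is needed for the effect. Compound 2 has the lowest of the two numbers; its nearest neighbour is compound 1, and the gap is within the scatter, so the two stand level. Among the measured compounds shown here, the one measured step, a 1.0-fold lower number from compound 1 to compound 2 (0.01 log units; within the scatter), changes only the ring on the aromatic nitrogen and leaves the read-out unmoved.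

Compound 3 `CC(C)c1onc(-c2c(Cl)cccc2Cl)c1COc1ccc(-c2nc3ccc(C(=O)O)cc3n2C2CCCC2)cc1` is the next member. It differs from compound 2 in one place: cyclopentyl in place of cyclobutyl on an aromatic nitrogen. The step of a 1.0-fold lower number from compound 1 to compound 2 (0.01 log units; within the scatter) bears directly on this change, since it also swaps one non-aromatic ring of carbon only for another of different size on that nitrogen, and it was flat. A ring that is larger than one measured ring and smaller than the other gives no ground to expect movement in this assay beyond the scatter, in either direction.

Compound 3 is therefore estimated at 14.5 nM, with a range from 7 nM to 30 nM. The step this estimate means, a 1.0-fold higher number from compound 2 to compound 3 (0.00 log units; within the scatter), is expected to stay within the scatter.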

Compound 3, half-maximal effective concentration: 13.6 nM
Compound 3: middle estimate off by 1.1-fold (0.03 log units), on the high side, and the stated range covers the measured number.
By their numbers in this assay, from the lowest: compounds 3, 2 and 1 (each within the scatter of the next).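

In this assay the cyclopentyl group on the aromatic nitrogen stands level with both other rings: a 1.1-fold lower number from compound 2 to compound 3 (0.02 log units; within the scatter) on the swap from cyclobutyl, and a 1.1-fold lower number from compound 1 to compound 3 (0.04 log units; within the scatter) on the swap from cycloheptyl. The earlier pair offered only one flat step between two ring sizes, whereas three compounds now give three flat comparisons, and cyclobutyl, cyclopentyl and cycloheptyl cannot be ranked in this assay; among these three compounds, the size of a non-aromatic ring of carbon only at this position shows no trend in either direction, and none of the three goes against this. No supporting data are available to explain why the read-out stays flat across these rings.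

The compounds shown leave open whether this tolerance extends beyond rings of carbon only, for example to a tetrahydropyranyl or piperidinyl ring, where a ring oxygen or ring nitrogen enters at this position. They also leave open how an open chain such as ethyl or a flat aromatic ring such as phenyl on the same nitrogen would compare with the three level compounds.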